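A few compounds are considered here, and "the series" means these few. Any claim that something is new, unique, unknown or untested is made for them only; others in the source may bear on it.

Working notes on the hydroxamic acid series.

Of the compounds shown here, three have been measured in an assay on Sf9 cells for inhibition of protein deacetylase HDAC6 (Homo sapiens), read by fluorescence, with a stated time of 40 min, tested at 100 nM; a lower number here means less inhibition, a higher number more inhibition at the concentration tested (going by the name of the read-out). Among the compounds with values here, compound 1 `Cc1ccccc1-n1nc(-c2ccccc2)nc1CNc1ccc(C(=O)NO)cc1` gives 57.1%, compound 3 `Cc1ccc(-n2nc(-c3ccccc3)nc2CNc2ccc(C(=O)NO)cc2)cc1` gives 60.7%, and the only pair that differs in one place, a number 3.6 percentage points higher from compound 1 to compound 3 (within the scatter), shows that moving the methyl on the aryl group attached to the aromatic nitrogen changes little. Compound 2 `COc1ccc(-c2nc(CNc3ccc(C(=O)NO)cc3)n(-c3ccccc3)n2)cc1` gives 77.6% and stands highest of the three, beyond the scatter from both compound 3 and compound 1.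

The next compound, compound 4 `O=C(NO)c1ccc(NCc2nc(-c3ccc(F)cc3)nn2-c2ccccc2)cc1`, is to be measured in this assay. It differs from compound 2 by fluoro in place of methoxy on an aromatic carbon. Within the data shown here, no measured step bears directly on this exchange: the single step in hand concerns the aryl group on the aromatic nitrogen, not the group on the aromatic carbon, and it was within the scatter. Compounds 1 and 3, which carry an unsubstituted phenyl at that position, sit well under compound 2, so the methoxy appears tied to the higher number, though both also carry a methylphenyl on the nitrogen, which clouds the comparison.

Compound 4 is therefore expected to fall below compound 2, by roughly a number 12.6 percentage points lower from compound 2 to compound 4 (beyond the scatter). The estimate for compound 4 is 65%, with a range from 50% to 80%.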

Compound 4, a percentage reported as inhibition, at one concentration (the size of the read-out at that concentration, not a potency): 70.9%
For compound 4 the middle estimate is 5.9 percentage points below the measured one; the range from low to high includes it.
By their numbers in this assay, from the lowest: compounds 1 and 3 (each within the scatter of the next); then compounds 4 and 2 (each within the scatter of the next).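

In this assay, fluoro in place of methoxy on an aromatic carbon, para to a large group, gives a number 6.7 percentage points lower from compound 2 to compound 4 (within the scatter), the first step read at this position, whereas the earlier step concerned only the aryl group on the aromatic nitrogen. The 4-methoxyphenyl and 4-fluorophenyl compounds therefore cannot be told apart here, even though the exchange replaces two heavy atoms with one and removes the single hydrogen-bond acceptor of the methoxy, so this pair gives no sign that methoxy in particular is needed at this position. Nothing in hand explains why the two groups read alike.

Still open is what either group adds over an unsubstituted phenyl at this position while the phenyl on the aromatic nitrogen stays the same, a comparison the compounds shown do not offer. Also open, going by these compounds, is whether a different group at the same place, such as an amine, a carboxylic acid or a longer alkoxy chain, would give a step beyond the scatter from compound 2 in this assay.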